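Aziridin-1-yl to (3-methoxypropyl)amino: second instance of the swap

A few compounds are considered here, and "the series" means these few. Any claim that something is new, unique, unknown or untested is made for them only; others in the source may bear on it.

Measured so far in a functional assay on NCI60 cells (Homo sapiens) for cytotoxicity; a lower number here means a stronger inhibitor of growth, a higher number a weaker inhibitor of growth:
compound 1, `O=C1C=C(N2CC2)C(=O)c2nc(-c3ccccc3)ccc21`: 3310 nM
compound 2, `COCCCNC1=CC(=O)c2nc(-c3ccccc3)ccc2C1=O`: 19100 nM
compound 3, `O=C1C(N2CC2)=CC(=O)c2nc(-c3ccccc3)ccc21`: 324 nM

Compound 3 gives the lowest number of the three in this assay, and its steps to both others lie beyond the scatter. Compound 1 has the same atoms as compound 3, joined differently; the difference between the two cores is not broken down here. Compound 2 differs from compound 3 in one place, ((3-methoxypropyl)amino in place of aziridin-1-yl on a double-bonded ring carbon), and this brought a 59-fold higher number from compound 3 to compound 2 (1.77 log units; beyond the scatter).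

Compound 4, `COCCCNC1=CC(=O)c2ccc(-c3ccccc3)nc2C1=O`, is not yet measured. It carries the same change, now made on the core of compound 1: (3-methoxypropyl)amino in place of aziridin-1-yl on a double-bonded ring carbon. Among the compounds with values here, the two place descriptions agree word for word, so the change is the same, but the surrounding core is the one of compound 1, not of compound 3.

From compound 1 the step to compound 4 is expected to be a 27-fold higher number from compound 1 to compound 4 (1.43 log units; beyond the scatter), a size resting on a 59-fold higher number from compound 3 to compound 2 (1.77 log units; beyond the scatter) and on the starting point of compound 1 at 3310 nM. Within the data shown here, only one earlier instance exists, so the width is kept large. For compound 4 the expected value in this assay is 90000 nM, between 25000 nM and 200000 nM.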

Compound 4, concentration for total growth inhibition: 28800 nM
The estimate for compound 4 lay 3.1-fold (0.49 log units) above the measured number; the measured number falls inside the stated range.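

In this assay the change from aziridin-1-yl to (3-methoxypropyl)amino gives an 8.7-fold higher number from compound 1 to compound 4 (0.94 log units; beyond the scatter) on this core, so the direction seen on the core of compound 3 recurs. The size does not carry over between the two cores: the same change on two cores in this assay, a 59-fold higher number (1.77 log units; beyond the scatter) from compound 3 to compound 2 and an 8.7-fold higher number (0.94 log units; beyond the scatter) from compound 1 to compound 4, 6.8-fold (0.83 log units) apart, beyond the scatter of two such steps. Two cores show that a step read on one cannot be moved unchanged to the other, but they give no general rule for the series and do not show what sets the size on either core.

The compounds shown carry only these two groups on the double-bonded ring carbon, so it stays open whether the higher numbers follow from losing the three-membered ring or from the chain that enters. A shorter open-chain amine such as methylamino, or a ring amine such as pyrrolidin-1-yl, on both cores would help separate these two readings and show whether the gap between the cores persists.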